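Removing the nitro group from a quinoline sulfonamide

A few compounds are considered here, and "the series" means these few. Any claim that something is new, unique, unknown or untested is made for them only; others in the source may bear on it.

Measured compounds:
compound 1, `COc1cc(NS(=O)(=O)c2ccc(C)cc2[N+](=O)[O-])c2ncccc2c1`: 6800 nM
compound 2, `Cc1ccc2cccc(NS(=O)(=O)c3cc([N+](=O)[O-])ccc3C)c2n1`: > 20000 nM
compound 3, `COc1cc(NS(=O)(=O)c2ccc(C)cc2[N+](=O)[O-])c2nc(C)ccc2c1`: > 10000 nM

The three compounds share a core carrying a sulfonamide-linked aryl ring. In an assay on OCI-Ly3 cells for activation of NF-kappa-B inhibitor alpha (Homo sapiens), read by a luciferase reporter (on this read-out higher numbers stand for an effect only at larger amounts of compound and lower numbers for an effect already at smaller amounts), compound 1 gives 6800 nM. For compound 2 the value of > 20000 nM is a limit of this assay, not a number. For compound 3 the value of > 10000 nM is likewise a limit; it sits at the limit of > 10000 nM in this assay, at which 1 of the 3 values shown sits, so compound 3 stands at the edge of what this assay resolves. The only single-point step among these compounds, an at least 1.4-fold higher number from compound 1 to compound 3 (0.16 log units; that floor lies within the scatter), is a floor that lies within the scatter.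

Compound 4, `COc1cc(NS(=O)(=O)c2ccc(C)cc2)c2nc(C)ccc2c1`, differs from compound 3 by hydrogen in place of nitro on an aromatic carbon. Within the data shown here, none of the measured steps involves the nitro group, so no step bears directly on this change; the only measured step concerns a methyl and was within the scatter. The expectation for compound 4 is therefore a step that the limit leaves unreadable from compound 3 to compound 4, that is, no change beyond the scatter, and compound 4 is estimated at 20000 nM, expected to fall between 5000 nM and 80000 nM, most likely again as a limit.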

Compound 4, half-maximal effective concentration: 20000 nM
The estimate for compound 4 equals the measured number at the digits printed, within the range that was stated.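

In this assay compound 3 gives > 10000 nM, which is a limit and not a number. Compound 4 gives 20000 nM, so the step between these two compounds cannot be read. The compounds shown leave open whether hydrogen in place of nitro changes the number in this assay at all.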